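This account rests on a few compounds, and the source may have more. Where it says the series, first, only, none or still open, it means among the compounds named here.

Working notes on the series. Compound 1 `COc1ccc(F)cc1CNCCCNc1ccnc2cc(CCc3ccccc3)ccc12` gives 9.47 in a physicochemical assay for acid dissociation. Compound 3 `c1ccc(CCc2ccc3c(NCCCNCc4ccco4)ccnc3c2)cc1` gives 9.47, and compound 2 `COc1ccc(Oc2ccc3c(NCCCNCc4ccco4)ccnc3c2)cc1` gives 9.28. Compound 1 stands level with compound 3 at the digits shown, the two together the highest of the three numbers; the measured steps are a number 0.19 log units higher from compound 2 to compound 3 (within the scatter) and no change at the digits printed from compound 1 to compound 3 (within the scatter), and the numbers of compound 1 and compound 2 lie within the scatter of each other.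

Compound 4 `COc1ccc(-c2ccc3c(NCCCNCc4cc(F)ccc4OC)ccnc3c2)cc1` differs from compound 1 by 4-methoxyphenyl in place of phenethyl on an aromatic carbon. The step that bears on it is the change on the same aromatic carbon, a number 0.19 log units higher from compound 2 to compound 3 (within the scatter), which stayed within the scatter. For compound 4 a step of a number 0.09 log units lower from compound 1 to compound 4 (within the scatter) in this assay is therefore expected, not beyond the scatter. Compound 4 is estimated at 9.38, within 9.05 to 9.7.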

Compound 4, acid dissociation constant: 9.47
Compound 4: middle estimate off by 0.09 log units, on the low side; low and high end bracket the measured number.
By their numbers in this assay, from the lowest: compounds 2, 1, 3 and 4 (each within the scatter of the next).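

In this assay, 4-methoxyphenyl in place of phenethyl on this aromatic carbon gives no change at the digits printed from compound 1 to compound 4 (within the scatter) with the 5-fluoro-2-methoxyphenyl group on the chain. The earlier step at this carbon was read with furan-2-yl there, so both steps at this position now stay within the scatter, one with each of the two groups. No measurement at hand offers an explanation for this result.

From the compounds shown here alone, whether a carboxylic acid or an amine on this aromatic carbon would move the number beyond the scatter stays open, as does the effect of a longer chain linking the two nitrogens.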